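The source may report more compounds than this note shows. Statements on the series, on what has been measured and on what is new or still open speak of the compounds shown alone.

Three measured compounds share one core and differ only in the group carried by the amine nitrogen. Compound 1 `Cc1ccc(NC2=CC(=O)c3c(nc4n3[C@H]3OC[C@@H](O)[C@H]3OC4)C2=O)cc1C` gives 4320 nM in a functional assay on HeLa cells (Homo sapiens) for inhibition, read by sulforhodamine B assay; a lower number here means a stronger inhibitor, a higher number a weaker inhibitor. Compound 2 `CCc1ccc(NC2=CC(=O)c3nc4n(c3C2=O)[C@H]2OC[C@@H](O)[C@H]2OC4)cc1` gives 3990 nM in this assay, and compound 3 `O=C1C=C(Nc2ccccc2)C(=O)c2c1nc1n2[C@H]2OC[C@@H](O)[C@H]2OC1` gives 5620 nM. Compound 1 thus holds the second highest of the three numbers; compound 2 sits nearest to it and compound 3 furthest, both within the scatter of the measurement. Among the compounds with values here, the one step that can be counted among them, hydrogen in place of ethyl on an aromatic carbon, is a 1.4-fold higher number from compound 2 to compound 3 (0.15 log units; within the scatter), so the substituents on that phenyl group have made no difference beyond the noise.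

Compound 4 `O=C1C(NC2CCCC2)=CC(=O)c2c1nc1n2[C@H]2OC[C@@H](O)[C@H]2OC1` has not yet been measured. It differs from compound 1 by cyclopentyl in place of 3,4-dimethylphenyl on an amine nitrogen. Within the data shown here, no measured step covers a change of this kind: the step from compound 2 to compound 3 only alters what sits on the aromatic ring, and here the ring itself gives way to cyclopentyl. Among the measured compounds shown here, the only guide is that the three anilines cluster tightly, which leaves the size and direction of this step open. The estimate for compound 4 in this assay is therefore centred on the cluster, 5500 nM with a range from 1500 nM to 25000 nM, which means an expected step of a 1.3-fold higher number from compound 1 to compound 4 (0.10 log units; within the scatter).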

Compound 4, half-maximal inhibitory concentration: > 16000 nM
Compound 4: only a limit was reported (the forecaster's own chance of this, stated with the estimate: 10%); middle value at least 2.9-fold (0.46 log units) from the limit.
By their numbers in this assay, from the lowest: compounds 2, 1 and 3 (each within the scatter of the next). At a limit, above all of these: compound 4.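

Cyclopentyl in place of 3,4-dimethylphenyl on the amine nitrogen is the first change among these compounds to move the number beyond the scatter in this assay, giving an at least 3.7-fold higher number from compound 1 to compound 4 (0.56 log units; beyond the scatter). Compounds 1, 2 and 3, which all carry a phenyl ring on this nitrogen, stand within the scatter of one another, so changing the substituents on that ring showed no effect, whereas this replacement of the ring itself weakens inhibition at least modestly. On these data alone, compound 4 has only a limit rather than a measured number, so the true size of the step stays unknown and only its lower bound is fixed: the limit of > 16000 nM in this assay, at which 1 of the 4 values shown sits.

This one change alters ring size, aromatic character and the count of heavy atoms together, so the compounds shown cannot separate these, and a cyclohexyl or benzyl group on the same amine nitrogen would bear on that question. They also leave open how a phenyl ring carrying a methoxy group, a hydroxyl group or a carboxylic acid would read, as only ethyl and methyl groups appear on the ring here.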